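Lengthening the side chain of compound 3

A few compounds are considered here, and "the series" means these few. Any claim that something is new, unique, unknown or untested is made for them only; others in the source may bear on it.

Values so far in a functional assay on HeLa cells (Homo sapiens) for cytotoxicity, read by WST assay, with a stated time of 48 h (a higher number here means a weaker inhibitor, a lower number a stronger inhibitor), are these:
compound 1 `COc1ccc([C@H](O)[C@H]2CO[C@H](c3ccc(OC)c(OC)c3)[C@@H](C/C=C/c3ccc(OC)c(OC)c3)C2)cc1` gives 46000 nM
compound 2 `COc1ccc(/C=C/C[C@H]2C[C@@H]([C@@H](O)c3ccc(OC)c(OC)c3)CO[C@@H]2c2ccc(OC)c(OC)c2)cc1` gives 12200 nM
compound 3 `C=CC[C@H]1C[C@@H]([C@@H](O)c2ccccc2)CO[C@@H]1c1ccccc1` gives 25400 nM

In this assay, compound 3 (25400 nM) lies within the scatter of compound 1 and has a higher number than compound 2, a gap beyond the scatter. Starting from compound 3, compound 4 (`O[C@@H](c1ccccc1)[C@H]1CO[C@H](c2ccccc2)[C@@H](C/C=C/C2CCCCC2)C1`) carries 2-cyclohexylethenyl in place of vinyl on a saturated chain carbon bound to a saturated ring carbon. The same difference can be read as allyl to 3-cyclohexylprop-2-en-1-yl.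

Among the measured compounds shown here, no two measured compounds differ in one place only, so the size of this change has not been seen directly. A small step towards a lower number is expected in this assay, possibly none beyond the scatter. This expectation rests only on the narrow range so far, whose ends are compound 2 (12200 nM) and compound 1 (46000 nM). The estimated value for compound 4 (17000 nM) comes with 6000 nM to 45000 nM as its expected range.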

Compound 4, half-maximal inhibitory concentration: 6440 nM
Estimate against measurement, compound 4: 2.6-fold (0.42 log units) above; low and high end bracket the measured number.
By their numbers in this assay, from the lowest: compounds 4 and 2 (each within the scatter of the next); then compounds 3 and 1 (each within the scatter of the next).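

In this assay, among the compounds shown here, the step from vinyl to 2-cyclohexylethenyl on a saturated chain carbon bound to a saturated ring carbon gives a 3.9-fold lower number from compound 3 to compound 4 (0.60 log units; beyond the scatter), the first change in one place alone that can be read. It shows that this position accepts a far bigger all-carbon group carrying a six-membered non-aromatic ring, and that the number falls rather than rises when that group enters. Nothing measured here bears on the reason for this step.

From the compounds shown here alone, whether the step depends on the cyclohexyl ring itself remains open, since an unsubstituted phenyl ring or a straight hexyl chain at its place could give a different number. Also open, going by these compounds, are the role of the retained double bond and the effect of an amine at the end of the chain.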